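Bromo Substitution on Two Related Spiro-Linked Oxindole Scaffolds

A few compounds are considered here, and "the series" means these few. Any claim that something is new, unique, unknown or untested is made for them only; others in the source may bear on it.

Measured compounds:
- compound 1, `O=C1N=C(N2N=C(c3ccccc3)CC2c2ccccc2O)S/C1=C1/C(=O)Nc2ccccc21`: 2070 nM
- compound 2, `O=C1N=C(N2N=C(c3ccccc3)CC2c2ccccc2O)S/C1=C1/C(=O)Nc2ccc(Br)cc21`: 230 nM
- compound 3, `COc1ccc(C2=NN(C3=NC(=O)/C(=C4\C(=O)Nc5ccccc54)S3)C(c3ccc(Cl)cc3)C2)cc1`: 100000 nM

All three compounds were tested in a functional assay on cells (Cancer cell lines, Homo sapiens) for cytotoxicity, read by sulforhodamine B assay, with a stated time of 48 h; on this read-out higher numbers stand for weaker inhibition of growth and lower numbers for stronger inhibition of growth. Compound 1 `O=C1N=C(N2N=C(c3ccccc3)CC2c2ccccc2O)S/C1=C1/C(=O)Nc2ccccc21` gives 2070 nM in this assay. Compound 2 `O=C1N=C(N2N=C(c3ccccc3)CC2c2ccccc2O)S/C1=C1/C(=O)Nc2ccc(Br)cc21` differs from compound 1 by a single change, (bromo in place of hydrogen on an aromatic carbon), and in this assay compound 2 gives 230 nM. That change produced a 9.0-fold lower number from compound 1 to compound 2 (0.95 log units; beyond the scatter), so the bromo-bearing compound is the stronger growth inhibitor of the pair.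

Compound 3 `COc1ccc(C2=NN(C3=NC(=O)/C(=C4\C(=O)Nc5ccccc54)S3)C(c3ccc(Cl)cc3)C2)cc1` is built on a different core: it carries a methoxy-substituted phenyl and a chloro-substituted phenyl on the pyrazoline part in place of the unsubstituted phenyl and hydroxy-substituted phenyl of compound 1. The difference between the two cores is not broken down here. In this assay compound 3 gives 100000 nM, the highest number of the three, far weaker than either compound 1 or compound 2.

Compound 4 `COc1ccc(C2=NN(C3=NC(=O)/C(=C4\C(=O)Nc5ccc(Br)cc54)S3)C(c3ccc(Cl)cc3)C2)cc1` is not yet measured. It is related to compound 3 by the same change that links compound 1 to compound 2: bromo in place of hydrogen on an aromatic carbon. The place of the change is described in the same words for both pairs. The expectation for compound 4 rests on a single observed step, a 9.0-fold lower number from compound 1 to compound 2 (0.95 log units; beyond the scatter), applied to a much weaker starting point. If the effect carries over, the expected step from compound 3 to compound 4 is a 6.7-fold lower number from compound 3 to compound 4 (0.82 log units; beyond the scatter), yielding an estimate for compound 4 in this assay of 15000 nM, with a range from 3000 nM to 100000 nM. The range is wide because the step of compound 1 to compound 2 a 9.0-fold lower number from compound 1 to compound 2 (0.95 log units; beyond the scatter) comes from one pair on a different core, and compound 3 may sit at the edge of what this assay resolves.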

Compound 4, concentration for 50% growth inhibition: 140 nM
For compound 4 the middle estimate is 110-fold (2.03 log units) above the measured one, outside the stated range (below it).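

In this assay, bromo in place of hydrogen on an aromatic carbon again gives stronger growth inhibition, with a 710-fold lower number from compound 3 to compound 4 (2.85 log units; beyond the scatter). The direction of the change therefore carried over from one core to the other, but its size did not, and the gap between the two steps is too large to put down to ordinary variation between repeated measurements: the same change on two cores in this assay, a 9.0-fold lower number (0.95 log units; beyond the scatter) from compound 1 to compound 2 and a 710-fold lower number (2.85 log units; beyond the scatter) from compound 3 to compound 4, 79-fold (1.90 log units) apart, beyond the scatter of two such steps In this series, then, a step measured on one core is a fair guide to direction but a poor guide to size on another core, although these two pairs do not show why the size differs or whether the direction would hold on a third core.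

The compounds shown leave open whether bromo is special or whether another group on that aromatic carbon, such as fluoro, methyl or an amine, would give a similar gain on each core. Also open, going by these compounds, is which difference between the cores governs the size of the step, the methoxy, the chloro or the hydroxy group, and compounds that differ in only one of these places would help to separate them.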